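This account rests on a few compounds, and the source may have more. Where it says the series, first, only, none or still open, it means among the compounds named here.

Compound 1 `O=C(/C=C\Nc1ccc(F)cc1)c1cn(-c2ccccc2)nc1-c1ccc(F)cc1` and compound 2 `O=C(/C=C\Nc1ccc(Cl)cc1)c1cn(-c2ccccc2)nc1-c1ccc(F)cc1` share one core and differ only by chloro in place of fluoro on an aromatic carbon. In a functional assay on U-87MG ATCC cells (Homo sapiens) for antiproliferative activity, read by MTT assay, with a stated time of 48 h (a higher number here means a weaker inhibitor, a lower number a stronger inhibitor), compound 1 gives 18200 nM, while compound 2 gives 8900 nM; the step of a 2.0-fold lower number from compound 1 to compound 2 (0.31 log units; beyond the scatter). Compound 3 `COc1cc(N/C=C\C(=O)c2cn(-c3ccccc3)nc2-c2ccc(F)cc2)cc(OC)c1OC` differs from compound 1 in more than one place, and the difference between the two cores is not broken down here. In this assay compound 3 gives 12600 nM, a value that lies within the scatter of both compound 2 and compound 1, so no order among these three is claimed. Compound 4 `COc1cc(N/C=C\C(=O)c2cn(-c3ccccc3)nc2-c2ccc(Cl)cc2)cc(OC)c1OC` has not yet been measured; it differs from compound 3 by chloro in place of fluoro on an aromatic carbon, the same change that separates compound 1 from compound 2, at a place described in the same words. Among the compounds with values here, compound 4 is expected to move a 1.7-fold lower number from compound 3 to compound 4 (0.23 log units; within the scatter), a step of about the size recorded from compound 1 to compound 2, an expectation that rests on the single step of a 2.0-fold lower number from compound 1 to compound 2 (0.31 log units; beyond the scatter) and is therefore held loosely. The estimate for compound 4 in this assay is 7500 nM, expected to fall between 3000 nM and 19000 nM.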

Compound 4, half-maximal inhibitory concentration: 17800 nM
For compound 4 the middle estimate is 2.4-fold (0.38 log units) below the measured one, within the range that was stated.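

In this assay, the step reads a 1.4-fold higher number from compound 3 to compound 4 (0.15 log units; within the scatter), so chloro in place of fluoro did not repeat on this core what it did on the core of compound 1, and the two steps differ: the same change on two cores in this assay, a 2.0-fold lower number (0.31 log units; beyond the scatter) from compound 1 to compound 2 and a 1.4-fold higher number (0.15 log units; within the scatter) from compound 3 to compound 4, 2.9-fold (0.46 log units) apart, beyond the scatter of two such steps

This shows that the step seen on one core could not simply be carried to the other for this pair of cores. It does not show why, since the place reads the same in words, yet in the structures the exchanged halogen sits on a different aromatic ring in each pair, and the two cores also differ elsewhere. Within the data shown here, with only two steps in one cell line, it also gives no rule for other cores.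

The compounds shown leave open whether the exchange would give matching steps if made on the same aromatic ring of both cores. They also leave open how a bromo group or an amine at that place would compare with chloro and fluoro.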